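The compounds below may be only part of what the source reports. "The series", "measured", "known", "first", "only" and "open" are said of these compounds alone.

Measured so far:
- compound 1 `COc1cc(CC(O)c2ccc(-c3ccc(CO)cc3)cc2)c([N+](=O)[O-])cc1OC` — in an ADME assay on HeLa Rh cells (Homo sapiens) for cytotoxicity, read by microscopy (a higher number here means that more compound is tolerated, a lower number that less compound is tolerated), only a limit, > 244000 nM
- compound 2 `COc1cc(CC(O)c2ccc(-c3ccc(C(F)(F)F)cc3)cc2)c([N+](=O)[O-])cc1OC` — in this assay a number, 4100 nM

Compound 1 gives no number in this assay; its value is a limit of the assay. Compound 2 therefore holds the only number shown; the other value sits at a limit (the limit of > 244000 nM in this assay, at which 1 of the 2 values shown sits). Within the data shown here, the single measured step, an at least 59-fold lower number from compound 1 to compound 2 (1.77 log units; beyond the scatter), is large and reaches beyond the scatter, though its true size is open since it starts from a limit.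

Compound 3 `COc1cc(CC(O)c2ccc(-c3ccc(C)cc3)cc2)c([N+](=O)[O-])cc1OC` differs from compound 2 by methyl in place of trifluoromethyl on an aromatic carbon. Among the measured compounds shown here, no measured step exchanges methyl for trifluoromethyl, so the only guide is that the group on the outer ring moved the number far, as in an at least 59-fold lower number from compound 1 to compound 2 (1.77 log units; beyond the scatter), and that methyl replaces the group which gave the lower number. The expectation is a value between the two measured ones, nearer to compound 2 than to the limit of compound 1, with wide uncertainty. Compound 3 is expected to give about 20000 nM in this assay, within 5000 nM to 120000 nM. The step of a 4.9-fold higher number from compound 2 to compound 3 (0.69 log units; beyond the scatter) is thus expected to run upward, beyond the scatter but well short of the measured step.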

Compound 3, half-maximal cytotoxic concentration: 4700 nM
Estimate against measurement, compound 3: 4.3-fold (0.63 log units) above, and the stated range ends above it.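

In this assay, methyl and trifluoromethyl on this aromatic carbon cannot be told apart: a 1.1-fold higher number from compound 2 to compound 3 (0.06 log units; within the scatter). The large step seen earlier therefore cannot be credited to trifluoromethyl itself, as the earlier pair alone might have suggested; two groups with different atoms, one of 4 heavy atoms and one of 1, give values within the scatter of each other. Among these compounds, the single change of hydrogen in place of hydroxy on the saturated chain carbon is itself large, an at least 51-fold lower number from compound 1 to compound 3 (1.71 log units; beyond the scatter), so within these three compounds the separation lies between hydroxymethyl on one side and methyl and trifluoromethyl on the other.

As far as these compounds go, whether the hydroxy of hydroxymethyl is specifically what matters remains open, as does the behaviour at this place of other groups, such as a methoxy, an amine or a carboxylic acid, which could fall with either side or elsewhere. The value of compound 1 is a limit, so the true size of both steps that start from it stays undefined: the limit of > 244000 nM in this assay, at which 1 of the 3 values shown sits.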